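Swapping Chloro for Fluoro on the Phenyl Ring

The compounds below may be only part of what the source reports. "The series", "measured", "known", "first", "only" and "open" are said of these compounds alone.

Among the measured compounds shown here, in a functional assay on PC-3 cells (Homo sapiens) for antiproliferative activity, read by MTT assay, with a stated time of 48 h (a lower number here means a stronger inhibitor, a higher number a weaker inhibitor), compound 1 (`Cc1ccc(S(=O)(=O)NC(=O)[C@H](CC(C)C)NC2=NC(=O)/C(=C/c3cccc(Cl)c3)S2)cc1`) gives 16.8 ug/mL and compound 2 (`Cc1ccc(S(=O)(=O)NC(=O)[C@H](CC(C)C)NC2=NC(=O)/C(=C/c3ccccc3Cl)S2)cc1`) gives 15.6 ug/mL so compound 2 stands level with the only other measured compound. Compound 3 (`Cc1ccc(S(=O)(=O)NC(=O)[C@H](CC(C)C)NC2=NC(=O)/C(=C/c3ccccc3F)S2)cc1`) carries one change from compound 2: fluoro in place of chloro on an aromatic carbon with fluoro in place of chloro on an aromatic carbon. For the measured compounds named here, the one measured step, 2-chlorophenyl in place of 3-chlorophenyl, is a 1.1-fold lower number from compound 1 to compound 2 (0.03 log units; within the scatter) and lies within the scatter. It is a different change, so it offers only weak guidance. The expected step is a 1.0-fold higher number from compound 2 to compound 3 (0.01 log units; within the scatter) and so none beyond the scatter. In this assay compound 3 is estimated at 16 ug/mL with an expected range from 9 ug/mL to 28 ug/mL on this reasoning.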

Compound 3, half-maximal inhibitory concentration: 15.3 ug/mL
Compound 3: middle estimate off by 1.0-fold (0.02 log units), on the high side; the measured number falls inside the stated range.
By their numbers in this assay, from the lowest: compounds 3, 2 and 1 (each within the scatter of the next).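

Fluoro in place of chloro, on an aromatic carbon ortho to a large group, gives a 1.0-fold lower number from compound 2 to compound 3 (0.01 log units; within the scatter), so this swap of one halogen for another shows no real difference at this position. The broader swap of 3-chlorophenyl for 2-fluorophenyl gives a 1.1-fold lower number from compound 1 to compound 3 (0.04 log units; within the scatter), which also shows no real difference. No measurement shown here explains this result.

Still open, as far as these compounds go, is whether a non-halogen group on this same carbon, such as an amine, a methoxy or a carboxylic acid, would give a step beyond the scatter.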